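Swapping a chlorine for a methyl on the outer phenyl ring

This account rests on a few compounds, and the source may have more. Where it says the series, first, only, none or still open, it means among the compounds named here.

The measured compounds, all tested in a functional assay on A549 cells (Homo sapiens) for inhibition, read by MTT assay, with a stated time of 24 h, tested at 10 uM; on this read-out lower numbers stand for less inhibition of growth and higher numbers for more inhibition of growth at the one concentration tested:
Compound 1 `CS(=O)(=O)c1ccc(-c2cnc3[nH]cc(-c4nnc(-c5ccncc5)o4)c(=O)c3c2)cc1` gives 12.1%.
Compound 2 `CS(=O)(=O)c1ccc(-c2cnc3[nH]cc(-c4nnc(-c5ccc(F)cc5)o4)c(=O)c3c2)cc1` gives 3.59%.
Compound 3 `CS(=O)(=O)c1ccc(-c2cnc3[nH]cc(-c4nnc(-c5ccc(Cl)cc5)o4)c(=O)c3c2)cc1` gives 26.8%.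

The three compounds share one core and differ only in the aromatic group hanging from the oxadiazole. Compound 3 stands highest of the three in this assay, and its distance to both others lies beyond the usual scatter. The step from the pyridin-4-yl of compound 1 to the 4-chlorophenyl of compound 3 reads a number 14.7 percentage points higher from compound 1 to compound 3 (beyond the scatter), the step from the fluorine of compound 2 to the chlorine of compound 3 reads a number 23.2 percentage points higher from compound 2 to compound 3 (beyond the scatter), and the step between compound 1 and compound 2 reads a number 8.5 percentage points lower from compound 1 to compound 2 (within the scatter).

Compound 4 `Cc1ccc(-c2nnc(-c3c[nH]c4ncc(-c5ccc(S(C)(=O)=O)cc5)cc4c3=O)o2)cc1` is not yet measured. Its difference from compound 3 is methyl in place of chloro on an aromatic carbon. Among the compounds with values here, none of the measured steps involves a methyl, so there is no direct precedent; what the measured steps show is that small changes at this position moved the read-out by modest amounts, and not always in the same direction. The expected step is therefore a number 8.8 percentage points lower from compound 3 to compound 4 (within the scatter), a small fall that could well sit within the scatter. Compound 4 is estimated at 18% in this assay, with a range from 4% to 34%.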

Compound 4, percent growth inhibition at one concentration: 11.2%
For compound 4 the middle estimate is 6.8 percentage points above the measured one; measured number inside the range.
By their numbers in this assay, from the lowest: compounds 2, 4 and 1 (each within the scatter of the next); then compound 3.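

In this assay, replacing chloro with methyl exchanges one heavy atom for one heavy atom, with no ring, hydrogen-bond donor or hydrogen-bond acceptor entering or leaving, yet it gives a number 15.6 percentage points lower from compound 3 to compound 4 (beyond the scatter) and so shows that even this small swap can register at this position. The 4-methylphenyl group does not stand apart from the other two groups that lie below the 4-chlorophenyl group, with a number 7.6 percentage points higher from compound 2 to compound 4 (within the scatter) and a number 0.9 percentage points lower from compound 1 to compound 4 (within the scatter) both printed as small steps, so among these four compounds only compound 3 stands apart. Nothing available here explains why chloro and methyl differ at this position.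

The compounds shown leave open whether bromo, methoxy, an amine or a carboxylic acid at this position would read like compound 3 or sit with the other three compounds. As far as these compounds go, all these numbers also come from a single concentration, so it remains open whether the same separation would hold at other concentrations or whether compound 1, compound 2 and compound 4 would then separate.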